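Swapping the aniline ring's substituents: fluoro, chloro, trifluoromethyl, methoxy

The source may report more compounds than this note shows. Statements on the series, on what has been measured and on what is new or still open speak of the compounds shown alone.

Measured so far: compound 1 `Fc1ccc(Nc2nc(SCc3ccc(C(F)(F)F)cc3)nc3ccccc23)cc1`, 7070 nM in a functional assay on PC-3 cells (Homo sapiens) for cytotoxicity, read by MTT assay, with a stated time of 72 h; a higher number here means a weaker inhibitor, a lower number a stronger inhibitor; compound 2 `FC(F)(F)c1ccc(CSc2nc(Nc3ccc(Cl)cc3)c3ccccc3n2)cc1`, 7110 nM; compound 3 `FC(F)(F)c1ccc(CSc2nc(Nc3ccc(C(F)(F)F)cc3)c3ccccc3n2)cc1`, 7880 nM.

Compound 3 stands beside the other two: the steps of a 1.1-fold higher number from compound 1 to compound 3 (0.05 log units; within the scatter) and a 1.1-fold higher number from compound 2 to compound 3 (0.04 log units; within the scatter) are both within the scatter, as is a 1.0-fold higher number from compound 1 to compound 2 (0.00 log units; within the scatter). Compound 4 `COc1ccc(Nc2nc(SCc3ccc(C(F)(F)F)cc3)nc3ccccc23)c(OC)c1` differs from compound 3 by 2,4-dimethoxyphenyl in place of 4-(trifluoromethyl)phenyl on a nitrogen on an aromatic ring. Going by the values given here, no measured step covers a methoxy group, so the three small halogen and trifluoromethyl swaps only suggest that this aniline ring tolerates change without shifting this assay much. Compound 4 is therefore expected to stay close, with the step of a 1.1-fold lower number from compound 3 to compound 4 (0.02 log units; within the scatter), giving an estimate of 7500 nM within a range of 2500 nM to 22000 nM.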

Compound 4, half-maximal inhibitory concentration: 32500 nM
Compound 4: middle estimate off by 4.3-fold (0.64 log units), on the low side; measured number outside the range, above it.
By their numbers in this assay, from the lowest: compounds 1, 2 and 3 (each within the scatter of the next); then compound 4.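

The aniline position is not as indifferent in this assay as the halogen and trifluoromethyl swaps alone suggested, since 2,4-dimethoxyphenyl on the nitrogen gives a step beyond the scatter against each earlier group (a 4.1-fold higher number from compound 3 to compound 4 (0.62 log units; beyond the scatter); a 4.6-fold higher number from compound 2 to compound 4 (0.66 log units; beyond the scatter); a 4.6-fold higher number from compound 1 to compound 4 (0.66 log units; beyond the scatter)). This change moves the number towards a weaker inhibitor. Nothing available explains why this change has this effect. Going by these compounds, both methoxy groups differ at once, so what a single methoxy group would do stays open. On these data alone, what an amine or a carboxylic acid on this ring would do also stays open.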